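Swapping the Amine Side Chain in a Receptor Agonist Series

The source may hold more compounds than are shown below. What is called first, only, known or untested is meant among the compounds shown, and "the series" means these compounds.

Three measured compounds share one core and differ only in the amine-bearing chain attached to the amide-type nitrogen. Compound 1 `CN[C@@H](CC(C)C)CN(C(=O)[C@@H]1C[C@H]1c1ccccc1)c1ccc(-c2ccccc2)cc1` gives 2 nM in a functional assay for agonist activity at G protein-coupled receptor 88 (Homo sapiens), read by HTRF and cAMP accumulation; on this read-out higher numbers stand for an effect only at larger amounts of compound and lower numbers for an effect already at smaller amounts. Compound 2 `CC(C)(N)CN(C(=O)[C@@H]1C[C@H]1c1ccccc1)c1ccc(-c2ccccc2)cc1` gives 1.4 nM in this assay, and compound 3 `CCC(CC)C(N)CCN(C(=O)[C@@H]1C[C@H]1c1ccccc1)c1ccc(-c2ccccc2)cc1` gives 2 nM. The steps among them are all small: a 1.4-fold lower number from compound 1 to compound 2 (0.15 log units; within the scatter), no change at the digits printed from compound 1 to compound 3 (within the scatter) and a 1.4-fold higher number from compound 2 to compound 3 (0.15 log units; within the scatter). Compound 3 thus sits level with compound 1 at the digits shown and within the scatter of compound 2, so no measured compound stands apart from the others on these numbers.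

Compound 4 `O=C([C@@H]1C[C@H]1c1ccccc1)N(CCNCC1CCCC1)c1ccc(-c2ccccc2)cc1` carries a further variation of the same chain: (cyclopentylmethyl)amino in place of 1-amino-2-ethylbutyl on a saturated chain carbon, two bonds along the chain from an amide-type nitrogen. Every measured step at this part of the molecule stayed within the scatter, so the change leading to compound 4 is expected to bring no step beyond the scatter in this assay, which is the meaning of a 1.3-fold higher number from compound 3 to compound 4 (0.10 log units; within the scatter). Compound 4 is therefore estimated at 2.5 nM, with a range from 0.7 nM to 8 nM.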

Compound 4, half-maximal effective concentration: 2.5 nM
Compound 4: middle estimate and measured number agree at the digits printed; measured number inside the range.
By their numbers in this assay, from the lowest: compounds 2, 1, 3 and 4 (each within the scatter of the next).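

For the compounds shown here, compound 4 is the first compound here whose chain holds a ring: (cyclopentylmethyl)amino enters with one five-membered non-aromatic ring of carbon only, in place of the open 1-amino-2-ethylbutyl with the same count of heavy atoms, and this assay shows a 1.3-fold higher number from compound 3 to compound 4 (0.10 log units; within the scatter). The comparisons with the other two chains agree, with a 1.8-fold higher number from compound 2 to compound 4 (0.25 log units; within the scatter) and a 1.3-fold higher number from compound 1 to compound 4 (0.10 log units; within the scatter), so at this position a ring of this kind reads the same as the open chains within the scatter. No supporting data explain this outcome.

Every chain shown carries an amine, so it remains open how a chain ending in a hydroxyl group or a carboxylic acid would read in this assay. As far as these compounds go, a phenyl ring in place of the cyclopentyl ring is likewise open.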